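Fluoropyridyl for fluorophenyl on a chromane sulfonamide series

The source may hold more compounds than are shown below. What is called first, only, known or untested is meant among the compounds shown, and "the series" means these compounds.

Measured so far:
compound 1 `O=S(=O)(Nc1nccs1)c1ccc2c(c1)OCC[C@@H]2c1ccc(C(F)(F)F)cc1-c1ccc(F)cc1` — 4.5
compound 2 `O=S(=O)(Nc1nccs1)c1ccc2c(c1)OCC[C@H]2c1ccc(C(F)(F)F)cc1-c1ccc(F)cc1` — 4.5

In a physicochemical assay for lipophilicity (on this read-out higher numbers stand for higher lipophilicity and lower numbers for lower lipophilicity), compound 1 gives 4.5 and compound 2 gives 4.5; the two stand level. The step of no change at the digits printed from compound 1 to compound 2 (within the scatter) is flat, which is consistent with the fact that compounds 1 and 2 differ only in the configuration as drawn.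

Compound 3 `O=S(=O)(Nc1nccs1)c1ccc2c(c1)OCC[C@@H]2c1ccc(C(F)(F)F)cc1-c1ccc(F)nc1` is not yet measured. It differs from compound 1 in one place: 6-fluoropyridin-3-yl in place of 4-fluorophenyl on an aromatic carbon. Going by the values given here, the only measured step, from compound 1 to compound 2, concerns configuration alone and does not bear on an aromatic ring exchange of this kind, so no step from can be applied directly. The change brings in one hydrogen-bond acceptor where none was present, and a ring with one hetero atom in place of a ring of carbon only.

On that basis compound 3 is expected to come out lower than compound 1 in this assay, an estimated step of a number 0.70 log units lower from compound 1 to compound 3 (beyond the scatter). The estimate for compound 3 is 3.8, with a range from 3.3 to 4.3.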

Compound 3, distribution coefficient: 3.2
Compound 3: the middle estimate sits 0.60 log units above what was measured; the whole stated range lies above it.
By their numbers in this assay, from the lowest: compound 3; then compounds 1 and 2 (each within the scatter of the next).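

At this position, ortho to a large group and meta to a trifluoromethyl group, this assay responds strongly to the ring exchange: 6-fluoropyridin-3-yl in place of 4-fluorophenyl gives a step of a number 1.30 log units lower from compound 1 to compound 3 (beyond the scatter). Going by these compounds alone, the earlier pair showed only a flat step in configuration, no change at the digits printed from compound 1 to compound 2 (within the scatter), so this is the first change to move the read-out beyond the scatter. Nothing measured here identifies what lies behind the size of this step.

As far as these compounds go, whether the same exchange gives a step of similar size on the configuration of compound 2 remains open. Also open, from the compounds shown here alone, is how the read-out would respond to a nitrile or a carboxylic acid on the same aromatic carbon in place of either ring.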